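The source may hold more compounds than are shown below. What is called first, only, known or untested is meant among the compounds shown, and "the series" means these compounds.

Measured in a functional assay on PC-3 cells (Homo sapiens) for antiproliferative activity, read by MTT assay, with a stated time of 72 h; a higher number here means a weaker inhibitor, a lower number a stronger inhibitor:
- Compound 1 `O=C(N/N=C/c1ccc(F)cc1)Nc1ccc(Oc2ccnc3[nH]ccc23)c(F)c1`: 2330 nM
- Compound 2 `COc1ccc(/C=N/NC(=O)Nc2ccc(Oc3ccnc4[nH]ccc34)c(F)c2)cc1`: 6730 nM
- Compound 3 `O=C(N/N=C/c1ccc(F)cc1)Nc1ccc(Oc2ccnc3[nH]ccc23)cc1`: 7490 nM

Compound 3, at 7490 nM, lies within the scatter of compound 2, at 6730 nM. Both are weaker than compound 1, and the gap to compound 3 is a 3.2-fold higher number from compound 1 to compound 3 (0.51 log units; beyond the scatter).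

Compound 4 `O=C(N/N=C/c1ccc(O)cc1Br)Nc1ccc(Oc2ccnc3[nH]ccc23)cc1` has 2-bromo-4-hydroxyphenyl in place of 4-fluorophenyl on a carbon with a double bond to nitrogen. Going by the values given here, no measured compound carries this group, so the evidence is indirect. Among the compounds with values here, the nearest precedent is methoxy in place of fluoro, which gave a 2.9-fold higher number from compound 1 to compound 2 (0.46 log units; beyond the scatter), a modest step towards a weaker inhibitor. The other measured step, a 3.2-fold higher number from compound 1 to compound 3 (0.51 log units; beyond the scatter), is also modest, but it lies in the core rather than in the group exchanged here. Neither step is large, so only a small change is expected in this assay, with no clear direction and nothing beyond the scatter. The expected step is a 1.1-fold higher number from compound 3 to compound 4 (0.03 log units; within the scatter). For compound 4 the estimated value is 8000 nM, with an expected range from 3000 nM to 22000 nM.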

Compound 4, half-maximal inhibitory concentration: "not active" (no number reported)
No number was reported for compound 4; the estimate stays without a comparison.
By their numbers in this assay, from the lowest: compound 1; then compounds 2 and 3 (each within the scatter of the next).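

In this assay, going by these compounds alone, compound 4 was reported as "not active", with no number, so no step from compound 3 to compound 4 can be read. The compounds shown leave open what 2-bromo-4-hydroxyphenyl does on its own. No measurement shown accounts for this result.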